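Aryl swap on the fused core: what compound 4 may give

A few compounds are considered here, and "the series" means these few. Any claim that something is new, unique, unknown or untested is made for them only; others in the source may bear on it.

Compound 1 `C=C(Br)C(=O)Nc1cccc(-c2cn3nc(-c4ccccc4)sc3n2)c1`: 960 nM
Compound 2 `C=C(Br)C(=O)Nc1cccc(-c2cn3nc(-c4cccc(OC)c4)sc3n2)c1`: 1200 nM
Compound 3 `COc1cccc(-c2nn3cc(-c4cccc(N)c4)nc3s2)c1`: a limit, > 250000 nM

In a functional assay on CCRF-CEM cells (Homo sapiens) for inhibition, read by cell counting, with a stated time of 3 days (a higher number here means a weaker inhibitor, a lower number a stronger inhibitor), compound 2 gives 1200 nM. Compound 1 lies within the scatter of it, a 1.3-fold higher number from compound 1 to compound 2 (0.10 log units; within the scatter). Compound 3 reaches only a limit, > 250000 nM. The step of an at least 200-fold higher number from compound 2 to compound 3 (2.31 log units; beyond the scatter) is the large one in this set.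

Compound 4 `C=C(Br)C(=O)Nc1cccc(-c2cn3nc(-c4ccc(Cl)cc4)sc3n2)c1` differs from compound 2 by 4-chlorophenyl in place of 3-methoxyphenyl on an aromatic carbon. The measured step that touches the same ring, a 1.3-fold higher number from compound 1 to compound 2 (0.10 log units; within the scatter), stayed within the scatter, so a change on that aromatic ring has so far moved the number little. The step of an at least 200-fold higher number from compound 2 to compound 3 (2.31 log units; beyond the scatter) concerns another part of the molecule and does not bear on it. Compound 4 is therefore expected to come out near compound 2, at an estimated 1000 nM, with a range from 400 nM to 2500 nM. The expected step of a 1.2-fold lower number from compound 2 to compound 4 (0.08 log units; within the scatter) lies within the scatter.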

Compound 4, half-maximal inhibitory concentration: 3200 nM
Compound 4: middle estimate off by 3.2-fold (0.51 log units), on the low side; measured number outside the range, above it.
By their numbers in this assay, from the lowest: compounds 1 and 2 (each within the scatter of the next); then compound 4. At a limit, above all of these: compound 3.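

In this assay, a 2.7-fold higher number from compound 2 to compound 4 (0.43 log units; beyond the scatter) and a 3.3-fold higher number from compound 1 to compound 4 (0.52 log units; beyond the scatter) show that a change on this aromatic ring can move the number beyond the scatter. Chloro in place of hydrogen in compound 4 thus has a measurable effect on the number at this ring, whereas the methoxy of compound 2 stayed within the scatter of compound 1. Nothing given here accounts for this shift.

The compounds shown do not separate the chloro group from its place on the ring. On these data alone, what an amine or a carboxylic acid on this ring would give also remains open.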